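The compounds below may be only part of what the source reports. "The series", "measured", "known", "first", "only" and "open" are said of these compounds alone.

The measured compounds in a functional assay on MCF7 cells (Homo sapiens) for inhibition, read by sulforhodamine B assay, with a stated time of 48 h (a higher number here means a weaker inhibitor of growth, a lower number a stronger inhibitor of growth), are these:

Compound 1 `COc1ccc(/C=C/C2(C)C=CC(=O)O2)c(OC)c1OC` gives 110000 nM in this assay.
Compound 2 `COc1c(O)ccc(/C=C/C2(C)C=CC(=O)O2)c1OC` gives 45300 nM in this assay.
Compound 3 `CC1(/C=C/c2ccccc2O)C=CC(=O)O1` gives 46200 nM in this assay.

Compound 1 and compound 2 differ by methyl in place of hydrogen on an oxygen on an aromatic ring, and that change gave a 2.4-fold higher number from compound 2 to compound 1 (0.39 log units; beyond the scatter). The difference between the core of compound 2 and the core of compound 3 is not broken down here; their values in this assay are within the scatter of each other, so no order is drawn between them.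

Compound 4 `COc1ccccc1/C=C/C1(C)C=CC(=O)O1` is not yet measured. It differs from compound 3 by methyl in place of hydrogen on an oxygen on an aromatic ring. The place of this change is the same, word for word, as the place of the change from compound 2 to compound 1, so it is taken as the same change, now made on the core of compound 3.

On this basis the step is expected to be a 2.3-fold higher number from compound 3 to compound 4 (0.36 log units; beyond the scatter), because the earlier step was a 2.4-fold higher number from compound 2 to compound 1 (0.39 log units; beyond the scatter). Compound 4 is therefore expected to give about 105000 nM in this assay, with an estimated range from 45000 nM to 250000 nM.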

Compound 4, concentration for total growth inhibition: 27000 nM
Compound 4: the middle estimate sits 3.9-fold (0.59 log units) above what was measured; the measured number lies below the stated range.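

In this assay, hydroxy to methoxy on the core of compound 3 gave a 1.7-fold lower number from compound 3 to compound 4 (0.23 log units; within the scatter) and so left no difference that can be told from the scatter. This shows that the size and direction of the step seen on the core of compound 2 did not carry over to the core of compound 3, and that the result of this change in this series depends on the core it is made on, as the two steps set side by side make plain: the same change on two cores in this assay, a 2.4-fold higher number (0.39 log units; beyond the scatter) from compound 2 to compound 1 and a 1.7-fold lower number (0.23 log units; within the scatter) from compound 3 to compound 4, 4.2-fold (0.62 log units) apart, beyond the scatter of two such steps. For the compounds shown here, with only two pairs, it does not show which part of the cores matters, nor how the change would read on any further core.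

The compounds shown leave open whether an amine or a carboxylic acid in place of the hydroxy group, or a longer chain than methyl on that oxygen, would follow either of the two steps. They also leave open whether the two cores would part in the same way in a cell line other than this one.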